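Ring size on the oxygen: compound 3 to compound 4

This account rests on a few compounds, and the source may have more. Where it says the series, first, only, none or still open, it means among the compounds named here.

In a functional assay on HT-29 cells (Homo sapiens) for inhibition, read by sulforhodamine B assay, with a stated time of 48 h (a higher number here means a weaker inhibitor of growth, a lower number a stronger inhibitor of growth), compound 3 `O=C(CCl)NC(=O)Nc1cccc(OC2CCCCC2)c1` gives 3800 nM. This lies within the scatter of compound 2 `O=C(CCl)NC(=O)Nc1cccc(OC2CCCC2)c1` at 3100 nM, and also of compound 1 `c1cc(NC2=NCCO2)cc(OC2CCCCCC2)c1` at 6900 nM, which carries cycloheptyl on a different core. Compound 4 `O=C(CCl)NC(=O)Nc1cccc(OC2CCCCCC2)c1` differs from compound 3 by cycloheptyl in place of cyclohexyl on an oxygen on an aromatic ring. Among the compounds with values here, the only measured step of this kind is a 1.2-fold higher number from compound 2 to compound 3 (0.09 log units; within the scatter), with cyclohexyl in place of cyclopentyl, and it stays within the scatter. No step beyond the scatter is therefore expected in this assay. The estimated step is a 1.1-fold higher number from compound 3 to compound 4 (0.02 log units; within the scatter). Compound 4 is expected at 4000 nM, with an estimated range of 2000 nM to 7500 nM.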

Compound 4, concentration for 50% growth inhibition: 6900 nM
For compound 4 the middle estimate is 1.7-fold (0.24 log units) below the measured one; low and high end bracket the measured number.
By their numbers in this assay, from the lowest: compounds 2, 3, 1 and 4 (each within the scatter of the next, the first and the last beyond it).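

In this assay, within the data shown here, the ring on the oxygen now runs from cyclopentyl to cycloheptyl on the shared core: a 1.8-fold higher number from compound 3 to compound 4 (0.26 log units; within the scatter) stays within the scatter, whereas a 2.2-fold higher number from compound 2 to compound 4 (0.35 log units; beyond the scatter) is the first step of this kind beyond it, and only a modest one. With cycloheptyl held constant, the exchange of the group on the nitrogen on an aromatic ring gives no change at the digits printed from compound 1 to compound 4 (within the scatter) and so no separation between the two cores. No supporting evidence bears on these steps.

As far as these compounds go, whether cyclobutyl or an open chain such as n-hexyl on the oxygen would follow the same trend remains open. So does the effect of a benzyl group at this position.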